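A few compounds are considered here, and "the series" means these few. Any claim that something is new, unique, unknown or untested is made for them only; others in the source may bear on it.

Measured compounds:
- compound 1 `CCOc1ccc(/C=C2\CN(CC(=O)O)c3c(C)cccc3C2=O)cc1`: 42.4%
- compound 2 `Cc1ccc2c(c1)C(=O)/C(=C/c1ccc(Br)cc1)CN2CC(=O)O`: 28.2%

In an assay on HL-60 cells for inhibition of glutathione S-transferase P (Homo sapiens), read by spectrophotometry, tested at 20 uM (a higher number here means more inhibition at the concentration tested (going by the name of the read-out), a lower number less inhibition), compound 1 gives 42.4%, the highest of the two numbers available; compound 2 in this assay gives 28.2%, a value lower than that of compound 1 by more than the usual scatter. Going by the values given here, no pair of measured compounds differs in a single place, so no measured step guides the change considered here.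

Compound 3 `Cc1ccc(/C=C2\CN(CC(=O)O)c3c(C)cccc3C2=O)cc1` is the unmeasured partner of compound 1. The change from compound 1 to compound 3 is methyl in place of ethoxy on an aromatic carbon. Nothing measured isolates this exchange; the only other data point, compound 2, carries a different core as well as a different group and cannot be read as a step.

Among the compounds with values here, with no step to lean on, the expected step from compound 1 to compound 3 is a small decrease, estimated as a number 8.4 percentage points lower from compound 1 to compound 3 (within the scatter), possibly within the scatter. For compound 3 in this assay the expected value is 34%, with a range from 16% to 50%.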

Compound 3, a percentage reported as inhibition, at one concentration (the size of the read-out at that concentration, not a potency): 46.8%
The estimate for compound 3 lay 12.8 percentage points below the measured number; low and high end bracket the measured number.
By their numbers in this assay, from the lowest: compound 2; then compounds 1 and 3 (each within the scatter of the next).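

Going by these compounds alone, at the aromatic carbon para to a large group, methyl in place of ethoxy gives the only measured single-place step in this assay, a number 4.4 percentage points higher from compound 1 to compound 3 (within the scatter). In this pair, ethoxy with its oxygen and longer chain can therefore give way to methyl without a change beyond the scatter, so neither feature is shown to be needed for the read-out at the concentration tested. Nothing available offers an explanation for this result.

Going by these compounds, only ethoxy and methyl are compared at this position, so it remains open whether an amine, a hydroxyl group or a longer chain such as butoxy would read alike. On these data alone, it is also open whether the same exchange would give a similar step on the core of compound 2.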